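Adding a Ring-Bearing Tail to Two Amide Cores

The compounds below may be only part of what the source reports. "The series", "measured", "known", "first", "only" and "open" are said of these compounds alone.

Compound 1 `NCCNC(=O)c1c(O)c2ccccc2n(-c2ccccc2)c1=O` and compound 3 `O=C(CCCCC1CCSS1)NCCNC(=O)c1c(O)c2ccccc2n(-c2ccccc2)c1=O` share one core; compound 3 carries an added group (a group of 11 heavy atoms (8 carbon, 1 oxygen, 2 sulfur; one five-membered non-aromatic ring with 2 hetero atoms) in place of a hydrogen atom, on an amine nitrogen). In a functional assay, with a stated time of 60 min, tested at 0.1 mM (a higher number here means a stronger effect of the compound at the concentration tested, a lower number a weaker effect), compound 1 gives 10% and compound 3 gives 7.8%, so the step of a number 2.2 percentage points lower from compound 1 to compound 3 (within the scatter) is within the scatter. Compound 2 `Cn1c(=O)c(C(=O)NCCCCCCN)c(O)c2ccccc21` is built on a different core; the difference between the two cores is not broken down here. In this assay compound 2 gives 8.3%, a number within the scatter of both compound 1 and compound 3. Compound 4 `Cn1c(=O)c(C(=O)NCCCCCCNC(=O)CCCCC2CCSS2)c(O)c2ccccc21` stands to compound 2 as compound 3 stands to compound 1: it carries the same change (a group of 11 heavy atoms (8 carbon, 1 oxygen, 2 sulfur; one five-membered non-aromatic ring with 2 hetero atoms) in place of a hydrogen atom, on an amine nitrogen), at a place described in the same words. Because the earlier step of a number 2.2 percentage points lower from compound 1 to compound 3 (within the scatter) lay within the scatter, and because compound 2 gives 8.3%, the corresponding step in this assay is expected to be small, a number 1.3 percentage points lower from compound 2 to compound 4 (within the scatter), beside the earlier one. Compound 4 is therefore estimated at 7% in this assay, with an expected range from 0% to 16%, resting on a single prior example of this change.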

Compound 4, a percentage reported as activity, at one concentration (the size of the read-out at that concentration, not a potency): 13%
Compound 4: middle estimate off by 6 percentage points, on the low side; the measured number falls inside the stated range.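

In this assay, the same added group on the core of compound 2 gives a step of a number 4.7 percentage points higher from compound 2 to compound 4 (within the scatter). Set beside the step on the other core, it shows no measurable difference in how the change behaves on the two cores: the same change on two cores in this assay, a number 2.2 percentage points lower (within the scatter) from compound 1 to compound 3 and a number 4.7 percentage points higher (within the scatter) from compound 2 to compound 4, 6.9 percentage points apart, within the scatter of two such steps

So, on both cores, adding this group on the amine nitrogen leaves the read-out within the usual scatter, and the two steps pointing different ways cannot be taken as a real reversal; what this does not show is that the group has no effect at all, since there are only two pairs, both read at a single concentration and both giving small numbers.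

On these data alone, it remains open whether the five-membered ring with its two sulfur atoms matters, or whether a plain acetyl group or a carboxylic acid on the same nitrogen would read the same. A longer chain between the core and the amine nitrogen is also an open case, as is whether any such change would produce a step beyond the scatter.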